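This account rests on a few compounds, and the source may have more. Where it says the series, first, only, none or still open, it means among the compounds named here.

Measured so far in a functional assay on HepG2 cells (Homo sapiens) for cytotoxicity, read by sulforhodamine B assay, with a stated time of 48 h; on this read-out lower numbers stand for stronger inhibition and higher numbers for weaker inhibition:
compound 1, `COc1ccc(/C=C/C(=O)c2cccc(-c3cccc(F)c3)c2)cc1`, 1720 nM
compound 2, `COc1cc(/C=C/C(=O)c2ccc(N)c(-c3ccc(F)cc3)c2)cc(OC)c1OC`, 4210 nM
compound 3, `COc1ccc(/C=C/C(=O)c2cccc(-c3cccc(F)c3)c2)cc1OC`, 1170 nM

Compound 4, `COc1ccc(/C=C/C(=O)c2ccc(N)c(-c3ccc(F)cc3)c2)cc1OC`, is not yet measured. It arises from compound 2 by hydrogen in place of methoxy on an aromatic carbon. The same kind of change is already on record between two measured compounds: compound 1 arises from compound 3 by hydrogen in place of methoxy on an aromatic carbon, and in this assay that step was a 1.5-fold higher number from compound 3 to compound 1 (0.17 log units; within the scatter). The two places are not identical in their surroundings: the place in compound 2 is also meta to a methoxy group (2 heavy atoms), which the place in compound 3 is not, so the change is of the same kind rather than the same. How the core of compound 2 differs from the core of compound 3 is not broken down here. Compound 2 gives the highest number of the three measured, and its gaps to compound 1 and to compound 3 lie beyond the scatter.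

For compound 4 the step is expected to be a 1.2-fold higher number from compound 2 to compound 4 (0.09 log units; within the scatter), set beside the earlier one and resting on a 1.5-fold higher number from compound 3 to compound 1 (0.17 log units; within the scatter). The estimated value for compound 4 is 5200 nM, with the expected range running from 2600 nM to 10500 nM.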

Compound 4, half-maximal inhibitory concentration: 3780 nM
Compound 4: the middle estimate sits 1.4-fold (0.14 log units) above what was measured; low and high end bracket the measured number.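

In this assay, hydrogen in place of methoxy on the core of compound 2 gives a 1.1-fold lower number from compound 2 to compound 4 (0.05 log units; within the scatter), a step that cannot be told apart from repeat-measurement noise. Set beside the earlier step, the two cores show no difference in their response to this change: the same change on two cores in this assay, a 1.5-fold higher number (0.17 log units; within the scatter) from compound 3 to compound 1 and a 1.1-fold lower number (0.05 log units; within the scatter) from compound 2 to compound 4, 1.6-fold (0.21 log units) apart, within the scatter of two such steps. Going by these compounds alone, in this series, the change can therefore be carried between these two cores as a step too small to read, but this rests on only two pairs, gives no reliable direction for the step, and shows nothing about any other core.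

The compounds shown leave open what other groups would do at this place on the aromatic ring, for instance a hydroxyl group, an ethoxy group or a longer chain. Also open, from the compounds shown here alone, is how the same change would read on a core carrying a nitrile or a carboxylic acid where compound 2 carries its amine.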